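The compounds below may be only part of what the source reports. "The series", "measured", "known", "first", "only" and "open" are said of these compounds alone.

compound 1 `COCC(=O)N[C@@H](C)c1ccc(NC(=O)[C@H]2C[C@@H]2c2cccnc2)cc1`: 43.2 mL.min-1.g-1
compound 2 `C[C@H](NC(=O)c1ccccc1)c1ccc(NC(=O)[C@H]2C[C@@H]2c2cccnc2)cc1`: 148 mL.min-1.g-1
compound 3 `C[C@H](NC(=O)c1ccc(C#N)cc1)c1ccc(NC(=O)[C@H]2C[C@@H]2c2cccnc2)cc1`: 53 mL.min-1.g-1

In an ADME assay on microsomes from liver (Mus musculus) for pharmacokinetics (on this read-out lower numbers stand for slow clearance and higher numbers for fast clearance), compound 3 gives 53 mL.min-1.g-1, which cannot be told apart from compound 1: a 1.2-fold higher number from compound 1 to compound 3 (0.09 log units; within the scatter). Compound 2 stands apart from both, with a 3.4-fold higher number from compound 1 to compound 2 (0.53 log units; beyond the scatter) and a 2.8-fold lower number from compound 2 to compound 3 (0.45 log units; beyond the scatter).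

Compound 4 `C[C@H](NC(=O)c1ccccn1)c1ccc(NC(=O)[C@H]2C[C@@H]2c2cccnc2)cc1` has pyridin-2-yl in place of 4-cyanophenyl on a carbonyl carbon. Going by the values given here, no measured step makes this exact swap, so the evidence is indirect. The closest guide is the pair that differs only by cyano in place of hydrogen on an aromatic carbon, a 2.8-fold lower number from compound 2 to compound 3 (0.45 log units; beyond the scatter). Compound 4 has no cyano group, which points towards compound 2 and its 148 mL.min-1.g-1. However, its ring also differs from the plain phenyl of compound 2, and none of the measured compounds shows what a ring with a hetero atom does here. A modest rise at most therefore seems likely, with compound 3 and its 53 mL.min-1.g-1 as the nearer anchor.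

The expected step is a 1.5-fold higher number from compound 3 to compound 4 (0.17 log units; within the scatter). The estimated value for compound 4 is 78 mL.min-1.g-1, with an expected range of 35 mL.min-1.g-1 to 170 mL.min-1.g-1.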

Compound 4, intrinsic clearance in microsomes: < 3.42 mL.min-1.g-1
Compound 4 ended at the assay's limit; the forecaster's own chance of this, stated with the estimate: 3%; middle value at least 22-fold (1.35 log units) from the limit.
By their numbers in this assay, from the lowest: compounds 1 and 3 (each within the scatter of the next); then compound 2. At a limit, below all of these: compound 4.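

In this assay compound 4 gives < 3.42 mL.min-1.g-1, which is a limit of the assay and not a number, and it stands alone there among the compounds shown: the limit of < 3.42 mL.min-1.g-1 in this assay, at which 1 of the 4 values shown sits.

On this carbonyl carbon, the swap of 4-cyanophenyl for pyridin-2-yl gives an at least 15-fold lower number from compound 3 to compound 4 (1.19 log units; beyond the scatter), the swap of phenyl for pyridin-2-yl gives an at least 43-fold lower number from compound 2 to compound 4 (1.63 log units; beyond the scatter), and the swap of methoxymethyl for pyridin-2-yl gives an at least 12-fold lower number from compound 1 to compound 4 (1.10 log units; beyond the scatter), so all three steps are large. The earlier compounds shown here showed only modest steps or none beyond the scatter at this position, and they gave no sign that a six-membered aromatic ring with one hetero atom in place of one of carbon only could bring such a large drop in clearance.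

Only one ring of this kind is shown, so it remains open whether pyridin-3-yl, pyridin-4-yl or pyrimidin-2-yl on the same carbonyl carbon would behave like pyridin-2-yl. As far as these compounds go, it is equally open whether the low clearance would survive an added group on the pyridine ring, such as a methyl, an amine or a carboxylic acid.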